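Extending methylamino to ethylamino on an oxamic acid series

A few compounds are considered here, and "the series" means these few. Any claim that something is new, unique, unknown or untested is made for them only; others in the source may bear on it.

Measured compounds:
Compound 1, `CN(C)c1cccc(NC(=O)C(=O)O)c1C#N`: 54.7%
Compound 2, `N#Cc1c(N)cccc1NC(=O)C(=O)O`: 21.2%
Compound 3, `CNc1cccc(NC(=O)C(=O)O)c1C#N`: 96%

In a functional assay on the whole organism for inhibition, with Rattus norvegicus as the target, at a dose of 1 mg/kg by the oral route (a lower number here means less inhibition, a higher number more inhibition at the dose given (going by the name of the read-out)), compound 3 stands highest of the three measured compounds, with compound 1 coming nearest and compound 2 furthest behind. The three compounds share one core and differ only in the group on the ring nitrogen: amino in compound 2, methylamino in compound 3 and dimethylamino in compound 1.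

Compound 4, `CCNc1cccc(NC(=O)C(=O)O)c1C#N`, has not yet been measured. It differs from compound 3 by methyl in place of hydrogen on a saturated chain carbon bound to a nitrogen on an aromatic ring, which, cut one bond further out, reads methylamino to ethylamino.

For the measured compounds named here, two measured steps bear on this. Going from compound 2 to compound 3 gave a number 74.8 percentage points higher from compound 2 to compound 3 (beyond the scatter), and going from compound 1 to compound 3 gave a number 41.3 percentage points higher from compound 1 to compound 3 (beyond the scatter). Both show that what sits on this nitrogen shifts the read-out by large amounts, yet neither adds a methyl on the chain carbon, so the direction for compound 4 is uncertain. Since compound 3 already lies near the top of the scale, compound 4 is expected to lose somewhat, a number 21 percentage points lower from compound 3 to compound 4 (beyond the scatter), with wide uncertainty. Compound 4 is estimated at 75%, within 40% to 100%.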

Compound 4, a percentage reported as inhibition, in the whole organism at one dose (the size of the read-out at that dose, not a potency): 58.9%
Compound 4: the middle estimate sits 16.1 percentage points above what was measured, within the range that was stated.
By their numbers in this assay, from the lowest: compound 2; then compounds 1 and 4 (each within the scatter of the next); then compound 3.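

In this assay a single added methyl on the saturated chain carbon matters a great deal, giving a number 37.1 percentage points lower from compound 3 to compound 4 (beyond the scatter) and showing that going from methylamino to ethylamino is far from a neutral extension. Putting the extra carbon on the chain or on the nitrogen gives readings that cannot be told apart, since ethylamino against dimethylamino gives a number 4.2 percentage points higher from compound 1 to compound 4 (within the scatter) and so the two stand together. Ethylamino still keeps a clear lead over the bare amino group, with a number 37.7 percentage points higher from compound 2 to compound 4 (beyond the scatter) and so, across these four compounds, the read-out does not simply rise as the group on this nitrogen grows but peaks sharply at methylamino in compound 3.

The compounds shown leave open how a longer chain such as propyl, a branched group such as isopropyl or a small ring such as cyclopropyl would read on this nitrogen, and so whether the fall seen with ethylamino continues. Nothing given here explains why one added methyl shifts this whole-animal read-out so strongly.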